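The source may hold more compounds than are shown below. What is called first, only, known or untested is meant among the compounds shown, and "the series" means these compounds.

In a functional assay on HL-60 cells (Homo sapiens) for cytotoxicity, read by MTT assay, with a stated time of 48 h (a higher number here means a weaker inhibitor, a lower number a stronger inhibitor), the three measured compounds stand as follows.
Compound 1, `Cc1ccc(Cn2c(/C=C3\SC(=S)N(CC(=O)O)C3=O)nc3ccc(F)cc32)cc1`, gives 1690 nM.
Compound 2, `COc1ccc2nc(/C=C3\SC(=S)N(CC(=O)O)C3=O)n(Cc3ccc(C)cc3)c2c1`, gives 1920 nM.
Compound 3, `O=C(O)CN1C(=O)/C(=C/c2nc3cc(F)ccc3n2Cc2ccccc2F)SC1=S`, is reported only as a limit of the assay, > 50000 nM, not as a number.

Compound 1 and compound 2 share one core and differ in a single place: methoxy in place of fluoro on an aromatic carbon. That change moved the value a 1.1-fold higher number from compound 1 to compound 2 (0.06 log units; within the scatter). Compound 3 is built on a different core; how the two cores differ is not broken down here. For compound 3 the assay gives only (the limit of > 50000 nM in this assay, at which 1 of the 3 values shown sits).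

Compound 4, `COc1ccc2c(c1)nc(/C=C1\SC(=S)N(CC(=O)O)C1=O)n2Cc1ccccc1F`, has not been measured. It comes from compound 3 by the same change, (methoxy in place of fluoro on an aromatic carbon), at the same place on the ring. The expected step is a step that the limit leaves unreadable from compound 3 to compound 4, because the earlier step of a 1.1-fold higher number from compound 1 to compound 2 (0.06 log units; within the scatter) stayed within the scatter. Compound 4 is therefore expected to give about 80000 nM, somewhere between 20000 nM and 300000 nM, and most likely to be reported once more only as a limit.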

Compound 4, half-maximal inhibitory concentration: 3410 nM
Beside the measured number, compound 4's estimate is 23-fold (1.37 log units) above it; measured number outside the range, below it.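

On the two cores in this assay, putting methoxy in place of fluoro did not give the same result, so the size of the step on one core cannot be carried over to the other in this series: the same change on two cores in this assay, a 1.1-fold higher number (0.06 log units; within the scatter) from compound 1 to compound 2 and an at least 14-fold lower number (1.16 log units; beyond the scatter) from compound 3 to compound 4, at least 16-fold (1.22 log units) apart, beyond the scatter of two such steps. Compound 3 stands at a limit of the assay, > 50000 nM, not at a number: the limit of > 50000 nM in this assay, at which 1 of the 4 values shown sits. The new step, an at least 14-fold lower number from compound 3 to compound 4 (1.16 log units; beyond the scatter), therefore gives only a smallest size, and with just two pairs it does not show which difference between the cores matters or how the change would behave on a third core.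

The compounds shown leave open whether another group at this place on the aromatic ring, such as an amine or an ethoxy group, would give a similar step on either core. They also leave open whether the large step seen on the core of compound 3 would recur on closely related cores.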